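The source may report more compounds than this note shows. Statements on the series, on what has been measured and on what is new or still open speak of the compounds shown alone.

Three related compounds have so far been tested in a functional assay on PC-3 cells (Homo sapiens) for cytotoxicity, read by MTT assay, with a stated time of 72 h; on this read-out lower numbers stand for stronger inhibition and higher numbers for weaker inhibition. Compound 1 `CNC(=O)c1cc(Oc2ccc(C(=O)/C=C/c3ccc(OC)c(OC)c3OC)cc2)ccn1` offers no number to work with, as its entry reads "not determined" (no result reported). Compound 2 `CNC(=O)c1cc(Oc2ccc(C(=O)/C=C/c3ccc([N+](=O)[O-])cc3)cc2)ccn1` gives 11100 nM, and compound 3 `CNC(=O)c1cc(Oc2ccc(/C=C/C(=O)c3ccc(Br)cc3)cc2)ccn1` gives 3560 nM. Compound 2 therefore holds the higher of the two available numbers, which means the weaker inhibition, and its gap to compound 3 lies beyond the usual scatter of repeated measurements.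

The next compound to consider is compound 4 `CNC(=O)c1cc(Oc2ccc(C(=O)/C=C/c3cccc(Cl)c3Cl)cc2)ccn1`. It differs from compound 2 in one place: on a double-bonded chain carbon bound to a double-bonded chain carbon, 2,3-dichlorophenyl stands in place of 4-nitrophenyl (2,3-dichlorophenyl in place of 4-nitrophenyl on a double-bonded chain carbon bound to a double-bonded chain carbon). Among the measured compounds shown here, no two measured compounds differ in just one place, so the data show no direct effect of a swap like this one. For the measured compounds named here, the only loose guide is compound 3, which also carries a halogen, bromine, and reads 3560 nM. A modest move toward stronger inhibition is expected, and the estimated step of a 2.2-fold lower number from compound 2 to compound 4 (0.35 log units; beyond the scatter) is small enough to carry real uncertainty. In this assay the estimated value for compound 4 is 5000 nM, with an expected range from 1800 nM to 15000 nM.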

Compound 4, half-maximal inhibitory concentration: > 50000 nM
Compound 4 gave a limit, no number (the forecaster's own chance of this, stated with the estimate: 3%); middle value at least 10-fold (1.00 log units) from the limit.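

In this assay compound 4 gives a limit of the assay and not a number: the limit of > 50000 nM in this assay, at which 1 of the 4 values shown sits.

Among the compounds shown here, this is the first direct reading of a single change. Placing 2,3-dichlorophenyl in place of 4-nitrophenyl, on a double-bonded chain carbon bound to a double-bonded chain carbon, gives an at least 4.5-fold higher number from compound 2 to compound 4 (0.65 log units; beyond the scatter). For the compounds shown here, the change therefore moves the read-out toward weaker inhibition, showing that the result at this place depends on which group sits there, something no earlier pair of compounds could show.

On these data alone, a single step cannot separate the effect of losing the 4-nitrophenyl group from the effect of bringing in the 2,3-dichlorophenyl group, and the true size of the step remains open beyond what the limit allows. Also open, as far as these compounds go, is how a plain phenyl ring, or a phenyl ring carrying an amine or a carboxylic acid, would read at this same place, which would help show whether inhibition can be recovered or improved there.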